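A Change on the Ring Nitrogen of Compound 2

The source may report more compounds than this note shows. Statements on the series, on what has been measured and on what is new or still open speak of the compounds shown alone.

Of the compounds shown here, three sharing one core have been measured in a functional assay on PC-9 cells (Homo sapiens) for inhibition, read by MTT assay, with a stated time of 48 h, tested at 10 uM; a higher number here means more inhibition at the concentration tested (going by the name of the read-out), a lower number less inhibition. Compound 1 `COc1ccc(OC)c(Nc2cc(NC(=O)Nc3c(Cl)cccc3Cl)ncn2)c1` gives 95%, compound 3 `CC(C)(C)c1cccc(Nc2cc(NC(=O)Nc3c(Cl)cccc3Cl)ncn2)c1` gives 87.1%, and compound 2 `COc1cc(NC(=O)Nc2cc(Nc3cccc(C(C)(C)C)c3)ncn2)cc(OC)c1` gives 68%. Compound 2 thus stands lowest of the three: compound 3 is nearest, and compound 1 furthest, both beyond the scatter. Going by the values given here, the one step recorded among them, a number 19.1 percentage points higher from compound 2 to compound 3 (beyond the scatter), concerns the group on the amide-type nitrogen and is modest in size.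

Compound 4 `COc1cc(NC(=O)Nc2cc(Nc3cc(I)ccc3OC)ncn2)cc(OC)c1` is not yet measured. It differs from compound 2 at the other nitrogen: 5-iodo-2-methoxyphenyl in place of 3-(tert-butyl)phenyl on a nitrogen on an aromatic ring. Among the compounds with values here, no measured step changes this position alone, so nothing directly bears on the change. What can be said is that compound 1 and compound 3, which share the same group on the amide-type nitrogen and differ only at this ring nitrogen, give values within the scatter of each other, which hints that the group here moves the read-out little. Compound 4 is therefore expected to stay close to compound 2, with a number 4 percentage points higher from compound 2 to compound 4 (within the scatter) not beyond the scatter in either direction. The estimate for compound 4 in this assay is 72%, ranging from 55% to 88%.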

Compound 4, a percentage reported as inhibition, at one concentration (the size of the read-out at that concentration, not a potency): 91%
Compound 4: the middle estimate sits 19 percentage points below what was measured; the whole stated range lies below it.
By their numbers in this assay, from the lowest: compound 2; then compounds 3, 4 and 1 (each within the scatter of the next).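

In this assay, the ring nitrogen proves not to be a silent position: with 3,5-dimethoxyphenyl held on the amide-type nitrogen, placing 5-iodo-2-methoxyphenyl there in place of 3-(tert-butyl)phenyl gives a number 23 percentage points higher from compound 2 to compound 4 (beyond the scatter). The two compounds carrying 2,6-dichlorophenyl on the amide-type nitrogen, compound 1 at 95% and compound 3 at 87.1%, lie within the scatter of each other, so the hint they gave does not hold for the pair of compound 2 and compound 4, although the two pairs do not exchange the same groups. Nothing available accounts for this step.

The entering group brings the iodine and the methoxy in together, so the compounds shown do not tell which of the two carries the step, or how a phenyl bearing only one of them would read. They also leave open what an amine or a carboxylic acid in place of the iodine would do, and whether 5-iodo-2-methoxyphenyl would read the same with 2,6-dichlorophenyl on the amide-type nitrogen.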